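A second fluoro at the limit of the assay

The source may hold more compounds than are shown below. What is called first, only, known or untested is meant among the compounds shown, and "the series" means these compounds.

In an ADME assay on HepG2 cells (Homo sapiens) for inhibition, read by resazurin assay, with a stated time of 48 h (a lower number here means that less compound is needed, a higher number that more compound is needed for the effect), compound 3 (`O=C(Nc1ccc2sc(-c3cccc(F)c3)nc2c1)N1CCCC1`) gives > 50000 nM as a limit of the assay, not a number. Compound 1 (`O=C(Nc1ccc2sc(-c3ccccc3F)nc2c1)N1CCCC1`) gives > 50000 nM as a limit too. Compound 2 (`O=C(Nc1ccc2sc(-c3ccccc3)nc2c1)N1CCCC1`) also gives > 50000 nM as a limit.

Compound 4 (`O=C(Nc1ccc2sc(-c3cccc(F)c3F)nc2c1)N1CCCC1`) has not yet been measured. It turns the 3-fluorophenyl of compound 3 into 2,3-difluorophenyl, with fluoro in place of hydrogen on an aromatic carbon, ortho to a fluoro group and ortho to a large group (fluoro in place of hydrogen on an aromatic carbon).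

Among the measured compounds shown here, the closest precedent, the same kind of swap, is a step that the two limits leave unreadable from compound 2 to compound 3 here. Moving the fluoro gives a step that the two limits leave unreadable from compound 1 to compound 3 and removing it gives a step that the two limits leave unreadable from compound 1 to compound 2 as well. For the measured compounds named here, no measured step therefore has a size, and the only guide is the limit of > 50000 nM in this assay, at which 3 of the 3 values shown sit, for these compounds.

In this assay no step beyond the scatter is expected, and no direction. The estimate is a number no higher from compound 3 to compound 4 (the limit leaves the size open) for this change. For compound 4 the estimated value is 50000 nM with an expected range from 20000 nM to 100000 nM as the likely span.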

Compound 4, half-maximal effective concentration: > 50000 nM
Compound 4: only a limit was reported; the forecaster's own chance of this, stated with the estimate: 85%; the middle value lies on the limit itself.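

In this assay compound 4 gives > 50000 nM as a limit of the assay, not a number. Among the compounds shown here, no step from compound 4 to compound 1, compound 2 or compound 3 can be read, because all four compounds stand at the same limit: the limit of > 50000 nM in this assay, at which 4 of the 4 values shown sit. The compounds shown leave open how far these four truly differ from one another.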